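An Aromatic Ring Returns to the Sulfur Chain

A few compounds are considered here, and "the series" means these few. Any claim that something is new, unique, unknown or untested is made for them only; others in the source may bear on it.

Compound 2 `C=CCSc1nc2nc(C)cc(N3CC[C@@H](C)[C@@H](N(C)c4ncnc5[nH]ccc45)C3)n2n1` stands at > 100000 nM in a toxicity assay on GES1 cells (Homo sapiens) for inhibition, read by MTT assay, with a stated time of 72 h (a lower number here means a stronger inhibitor, a higher number a weaker inhibitor), which is a limit and not a number. Compound 1 `Cc1cc(N2CC[C@@H](C)[C@@H](N(C)c3ncnc4[nH]ccc34)C2)n2nc(SCCc3ccccc3)nc2n1` gives 66200 nM in this assay. Going by the values given here, the only measured step, with vinyl in place of benzyl on a saturated chain carbon bound to a sulfur, is an at least 1.5-fold higher number from compound 1 to compound 2 (0.17 log units; that floor lies within the scatter). Compound 3 `COc1ccc(CSc2nc3nc(C)cc(N4CC[C@@H](C)[C@@H](N(C)c5ncnc6[nH]ccc56)C4)n3n2)cc1` has 4-methoxyphenyl in place of vinyl at that carbon (4-methoxyphenyl in place of vinyl on a saturated chain carbon bound to a sulfur). Compound 1 also has an aromatic ring in this group, so a number near its 66200 nM seems likely. The expected change, toward a lower number, is small: an at least 1.4-fold lower number from compound 2 to compound 3 (0.15 log units; that floor lies within the scatter). For compound 3, the estimate is 70000 nM, with an expected range of 30000 nM to 120000 nM.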

Compound 3, half-maximal inhibitory concentration: > 100000 nM
Compound 3: no number, only a limit; the forecaster's own chance of this, stated with the estimate: 35%; at least 1.4-fold (0.15 log units) between middle value and limit.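

With 4-methoxyphenyl on the saturated chain carbon bound to a sulfur, compound 3 gives only a limit in this assay, not a number, so an aromatic ring here does not by itself bring a readable value. Going by these compounds alone, the one readable step is an at least 1.5-fold higher number from compound 1 to compound 3 (0.17 log units; that floor lies within the scatter). The step from vinyl to 4-methoxyphenyl cannot be read, because both ends are limits: the limit of > 100000 nM in this assay, at which 2 of the 3 values shown sit.

As far as these compounds go, how far compound 2 and compound 3 lie past that limit stays open. So does whether an amine or a carboxylic acid on this chain would give a readable number.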